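A few compounds are considered here, and "the series" means these few. Any claim that something is new, unique, unknown or untested is made for them only; others in the source may bear on it.

Working notes on the series. All compounds share one core and differ only in the substituent on an amine nitrogen in a ring. Compound 1 `Cc1ccc(N2CCN(C(=O)[C@H]3[C@@H](c4ccc(Cl)cc4)CCN3C(C)C)CC2)c([C@@H](N)C(C)C)c1` carries isopropyl there, and in an assay on HEK293 cells for displacement of a labelled ligand from Melanocortin receptor 4 (Homo sapiens) (on this read-out higher numbers stand for weaker inhibition and lower numbers for stronger inhibition), compound 1 gives 110 nM. Compound 2 `Cc1ccc(N2CCN(C(=O)[C@H]3[C@@H](c4ccc(Cl)cc4)CCN3C)CC2)c([C@@H](N)C(C)C)c1` carries methyl, and compound 2 gives 160 nM. Compound 3 `Cc1ccc(N2CCN(C(=O)[C@H]3[C@@H](c4ccc(Cl)cc4)CCN3C(=O)OC(C)C)CC2)c([C@@H](N)C(C)C)c1` carries isopropoxycarbonyl, and compound 3 gives 12 nM, the lowest of the three numbers. The steps to it are a 9.2-fold lower number from compound 1 to compound 3 (0.96 log units; beyond the scatter) and a 13-fold lower number from compound 2 to compound 3 (1.12 log units; beyond the scatter), whereas a 1.5-fold higher number from compound 1 to compound 2 (0.16 log units; within the scatter).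

Compound 4 `Cc1ccc(N2CCN(C(=O)[C@H]3[C@@H](c4ccc(Cl)cc4)CCN3C(=O)C(C)(C)C)CC2)c([C@@H](N)C(C)C)c1` is not yet measured. The change from compound 3 is tert-butyl in place of isopropoxy on a carbonyl carbon, so the carbonyl carbon attached to the amide-type nitrogen in the ring stays and only the group on that carbonyl changes. Among the compounds with values here, no measured step covers this exact change. The two steps that bear on it both show the carbonyl-bearing substituent giving the lower number, a feature compound 4 keeps, so no step beyond the scatter is expected, in either direction. Compound 4 is therefore expected near 15 nM, within 5 nM to 50 nM. This estimate means an expected step of a 1.3-fold higher number from compound 3 to compound 4 (0.10 log units; within the scatter).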

Compound 4, inhibition constant: 7.2 nM
Compound 4: the middle estimate sits 2.1-fold (0.32 log units) above what was measured; the measured number falls inside the stated range.
By their numbers in this assay, from the lowest: compounds 4 and 3 (each within the scatter of the next); then compounds 1 and 2 (each within the scatter of the next).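

In this assay, tert-butyl takes the place of isopropoxy on the carbonyl carbon with a 1.7-fold lower number from compound 3 to compound 4 (0.22 log units; within the scatter), so the oxygen and the hydrogen-bond acceptor counted in isopropoxy are not needed to keep the number at this level. Compound 4 gives a second carbonyl-bearing substituent on the amine nitrogen in a ring, with a 22-fold lower number from compound 2 to compound 4 (1.35 log units; beyond the scatter) and a 15-fold lower number from compound 1 to compound 4 (1.18 log units; beyond the scatter). Among these four compounds, both carbonyl-bearing substituents therefore give lower numbers than methyl and isopropyl, and no compound shown goes against this.

Nothing available accounts for these steps. From the compounds shown here alone, it remains open how a carbonyl carrying a longer chain, a phenyl ring or an amine would read at this position, and whether a sulfonyl group on the same nitrogen could stand in for the carbonyl.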